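The compounds below may be only part of what the source reports. "The series", "measured", "known", "first", "only" and "open" are said of these compounds alone.

Working notes on the series. The series shares one core, shown in compound 1 `COc1cccc(C(=O)Nc2ncc(Cc3cccc(C(F)(F)F)c3)s2)c1`, which carries a methoxy group on the benzamide ring and a trifluoromethyl group on the benzyl ring. In an assay on microsomes for inhibition of acyl-CoA desaturase 1 (Mus musculus), with a stated time of 60 min (on this read-out lower numbers stand for stronger inhibition and higher numbers for weaker inhibition), compound 1 gives 193 nM. Compound 2 `COc1ccc(C(=O)Nc2ncc(Cc3cccc(C(F)(F)F)c3)s2)cc1` keeps the same core and the same methoxy group, moved to another position on the benzamide ring. In this assay compound 2 gives "not determined" (no result reported), so there is no single number to place it against compound 1; the only anchor for this part of the series is compound 1.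

The step from compound 2 to compound 3 `COc1ccc(C(=O)Nc2ncc(Cc3cccc(C(F)(F)F)c3)s2)cc1OCC(C)(C)O` consists of 2-hydroxy-2-methylpropoxy in place of hydrogen on an aromatic carbon. Among the compounds with values here, no measured pair covers a change of this kind, and compound 2 itself has no number, so the size of the step cannot be taken from the data. The expectation in this assay is a step of no more than moderate size, in either direction, and possibly none beyond the scatter, with compound 1 as the reference point. On that basis compound 3 is estimated at 150 nM, with a range from 30 nM to 800 nM.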

Compound 3, half-maximal inhibitory concentration: > 9990 nM
Compound 3: a limit, no number (the forecaster's own chance of this, stated with the estimate: 10%); middle value at least 66-fold (1.82 log units) away from the limit.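

No step can be read from compound 2 to compound 3, as compound 2 has no number in this assay. Compound 3 gives > 9990 nM, which is a limit and not a number. The compounds shown leave open how far 2-hydroxy-2-methylpropoxy in place of hydrogen shifts this read-out, and where compound 2 stands against compound 1.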